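A few compounds are considered here, and "the series" means these few. Any claim that something is new, unique, unknown or untested is made for them only; others in the source may bear on it.

In a functional assay on MIA PaCa-2 cells (Homo sapiens) for antiproliferative activity (on this read-out lower numbers stand for an effect already at smaller amounts and higher numbers for an effect only at larger amounts of compound), compound 1 (`CC#CCNC(=O)c1cccc2c1cc(C)n2-c1nc2c(c(NCc3ccccc3)n1)CCCC2`) gives 723 nM and compound 2 (`C=CC#CC(=O)Nc1cccc2c1cc(C)n2-c1nc2c(c(NCc3ccccc3)n1)CCCC2`) gives 892 nM, so compound 2 stands within the scatter of compound 1. The next compound is compound 3 (`CCC(=O)Nc1cccc2c1cc(C)n2-c1nc2c(c(NCc3ccccc3)n1)CCCC2`), with a group of 2 heavy atoms (2 carbon; no ring) in place of a group of 4 heavy atoms (4 carbon; no ring), on a carbonyl carbon. The double bond and triple bond leave with the departing group. Within the data shown here, the only measured step, a 1.2-fold higher number from compound 1 to compound 2 (0.09 log units; within the scatter), lies within the scatter and gives no direct measure of this change, so a modest move to a higher number is expected, with wide uncertainty. The expected step is a 1.7-fold higher number from compound 2 to compound 3 (0.23 log units; within the scatter). For compound 3 the estimated value is 1500 nM, with an expected range of 500 nM to 5000 nM.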

Compound 3, half-maximal effective concentration: 1010 nM
Beside the measured number, compound 3's estimate is 1.5-fold (0.17 log units) above it, within the range that was stated.
By their numbers in this assay, from the lowest: compounds 1, 2 and 3 (each within the scatter of the next).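

In this assay, ethyl on the carbonyl carbon in place of the unsaturated four-carbon group leaves the number within the scatter (a 1.1-fold higher number from compound 2 to compound 3 (0.05 log units; within the scatter)). The wider comparison, on the aromatic carbon, also stays within the scatter (a 1.4-fold higher number from compound 1 to compound 3 (0.15 log units; within the scatter)), so the double bond and triple bond outside aromatic rings are not required for a number in this range. No available data bear on the reason for this result.

On these data alone, whether any group on the carbonyl carbon moves the number beyond the scatter remains open. A longer alkyl chain, a chain ending in an amine, or a carboxylic acid could test this.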